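A Large Amide Group on a Weak Acid

This account rests on a few compounds, and the source may have more. Where it says the series, first, only, none or still open, it means among the compounds named here.

Going by the values given here, in a functional assay on NCI-H441 cells (Homo sapiens) for antiproliferative activity, with a stated time of 24 h (a higher number here means a weaker inhibitor, a lower number a stronger inhibitor), compound 1 `O=C(O)CCC(=O)N1C/C(=C\c2ccccc2F)C(=O)/C(=C/c2ccccc2F)C1` gives 69000 nM, at the weak end of the three numbers known. Compound 3 `CC(=O)N1C/C(=C\c2ccccc2F)C(=O)/C(=C/c2ccccc2F)C1` gives 54000 nM, and a 1.3-fold lower number from compound 1 to compound 3 (0.11 log units; within the scatter) stays within the scatter. Compound 2 `O=C(O)/C=C/C(=O)N1C/C(=C\c2ccccc2F)C(=O)/C(=C/c2ccccc2F)C1` gives 29000 nM, and a 1.9-fold higher number from compound 2 to compound 3 (0.27 log units; within the scatter) also stays within it. Compound 4 `O=C(CCC(=O)N1C/C(=C\c2ccccc2F)C(=O)/C(=C/c2ccccc2F)C1)N[C@@H]1[C@@H](O)[C@H](O)[C@@H](CO)O[C@H]1O` has (2,4,5-trihydroxy-6-(hydroxymethyl)oxan-3-yl)amino in place of hydroxy on a carbonyl carbon. The measured steps all changed the group on the same amide carbonyl, and the largest, a 2.4-fold lower number from compound 1 to compound 2 (0.38 log units; beyond the scatter), is modest. None of them adds a group like this one, so only a small change in this assay is expected, with wide uncertainty. The expected result is a 1.4-fold lower number from compound 1 to compound 4 (0.14 log units; within the scatter). Compound 4 is estimated at 50000 nM, with an expected range from 15000 nM to 120000 nM.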

Compound 4, half-maximal inhibitory concentration: 79000 nM
Beside the measured number, compound 4's estimate is 1.6-fold (0.20 log units) below it; the measured number falls inside the stated range.
By their numbers in this assay, from the lowest: compounds 2, 3, 1 and 4 (each within the scatter of the next, the first and the last beyond it).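

In this assay, putting (2,4,5-trihydroxy-6-(hydroxymethyl)oxan-3-yl)amino in place of hydroxy on this carbonyl carbon gives a 1.1-fold higher number from compound 1 to compound 4 (0.06 log units; within the scatter). This position therefore accepts a group carrying a whole six-membered ring, far larger than any earlier change here, with no shift beyond the scatter. Nothing available explains why the number holds steady.

From the compounds shown here alone, it remains open whether a small amine in place of the hydroxy would behave the same way. A longer chain between the two carbonyl groups is also untested among these compounds.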